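The source may hold more compounds than are shown below. What is called first, only, known or untested is meant among the compounds shown, and "the series" means these compounds.

Series notes, N-methyl anilino compounds on the shared core. Compound 1 `CSc1ccc(Nc2ncnc3occ(C)c23)cc1` gives "not determined" (no result reported) in a functional assay on MDA-MB-435 cells (Homo sapiens) for inhibition, read by sulforhodamine B assay, with a stated time of 48 h (a lower number here means that less compound is needed, a higher number that more compound is needed for the effect), so no result is reported for it. Within the data shown here, compound 2 `CSc1ccc(N(C)c2ncnc3occ(C)c23)cc1` gives 12.3 nM in this assay, the only number in the set, so it stands alone as the reference point. Compound 3 `CCc1ccc(N(C)c2ncnc3occ(C)c23)cc1` differs from compound 2 by ethyl in place of methylsulfanyl on an aromatic carbon, the change sitting on an aromatic carbon of the six-membered aromatic ring of carbon only. Among the measured compounds shown here, no comparable step is available in the set. The expectation for this change is a modest loss, a 3.3-fold higher number from compound 2 to compound 3 (0.51 log units; beyond the scatter), likely beyond the scatter but not large. Compound 3 is estimated at 40 nM, with a range from 10 nM to 150 nM.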

Compound 3, half-maximal effective concentration: 183 nM
Beside the measured number, compound 3's estimate is 4.6-fold (0.66 log units) below it, and the stated range ends below it.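

In this assay the aromatic carbon para to a large group proves sensitive to this exchange: ethyl in place of methylsulfanyl, with the heavy-atom count unchanged at 2, gives a 15-fold higher number from compound 2 to compound 3 (1.17 log units; beyond the scatter). Methylsulfanyl and ethyl are therefore not interchangeable at this position, which compound 2 alone could not show. Nothing available here bears on what lies behind the step. Going by these compounds, whether methoxy, an amine or a longer chain at this position would read closer to compound 2 or compound 3 remains open.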